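A few compounds are considered here, and "the series" means these few. Any claim that something is new, unique, unknown or untested is made for them only; others in the source may bear on it.

Compound 2 `Cc1ccc(-c2cc(NC(=O)/C=C/c3ccc(Br)cc3)n[nH]2)cc1` is measured in a functional assay on B16-F10 cells (Mus musculus) for antiproliferative activity, read by MTT assay, with a stated time of 48 h (a higher number here means a weaker inhibitor, a lower number a stronger inhibitor), where compound 2 gives 1570 nM, the highest of the three numbers, although its gaps to the other two lie within the scatter. Compound 1 `Cc1ccc(-c2cc(NC(=O)/C=C/c3ccc(C(F)(F)F)cc3)n[nH]2)cc1` gives 1210 nM and compound 3 `Cc1ccc(-c2cc(NC(=O)/C=C/c3ccc(Cl)cc3)n[nH]2)cc1` gives 1520 nM. The measured steps of a 1.3-fold higher number from compound 1 to compound 2 (0.11 log units; within the scatter), a 1.3-fold higher number from compound 1 to compound 3 (0.10 log units; within the scatter) and a 1.0-fold lower number from compound 2 to compound 3 (0.01 log units; within the scatter) all lie within the scatter and all concern the substituent on the cinnamoyl ring, not the group changed here. Compound 4 `O=C(/C=C/c1ccc(Br)cc1)Nc1cc(-c2ccccc2)[nH]n1` differs from compound 2 by hydrogen in place of methyl on an aromatic carbon. No measured step touches this position, and since the shown steps were all small, a step within the scatter is expected. Compound 4 is estimated at 1700 nM, in the range 800 nM to 3600 nM, which means an expected step of a 1.1-fold higher number from compound 2 to compound 4 (0.03 log units; within the scatter).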

Compound 4, half-maximal inhibitory concentration: 1380 nM
The estimate for compound 4 lay 1.2-fold (0.09 log units) above the measured number, within the range that was stated.
By their numbers in this assay, from the lowest: compounds 1, 4, 3 and 2 (each within the scatter of the next).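

Going from 4-methylphenyl to phenyl gives a 1.1-fold lower number from compound 2 to compound 4 (0.06 log units; within the scatter) in this assay, the only step shown at this position. With bromo held in place, removing the methyl group leaves the number within the scatter, so this position, like the substituent on the other aromatic ring, shows no step beyond it. No evidence is available on why this is so. As far as these compounds go, whether an amine, a methoxy group or a carboxylic acid in place of the methyl group would move the number remains open. Also open, from the compounds shown here alone, is whether hydrogen in place of methyl gives a similar step when trifluoromethyl or chloro replaces bromo.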